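A Phenyl-to-Ethyl Swap in Growth Inhibition

A few compounds are considered here, and "the series" means these few. Any claim that something is new, unique, unknown or untested is made for them only; others in the source may bear on it.

Compound 1 `CC1CCC(C(C)C)C(OC(=O)C#CC(O/C=C/C(=O)OC2CC(C)CCC2C(C)C)C(C)C)C1`: > 100000 nM (a limit, not a number)
Compound 2 `COC(=O)C#CC(O/C=C/C(=O)OC)C(C)c1ccccc1`: 490 nM

Among the measured compounds shown here, in a functional assay on HBL-100 cells (Homo sapiens) for antiproliferative activity, read by sulforhodamine B assay, with a stated time of 48 h (on this read-out lower numbers stand for stronger inhibition of growth and higher numbers for weaker inhibition of growth), compound 2 gives 490 nM and holds the only actual number so far. The entry for compound 1 is a limit, so it offers no exact point of comparison.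

Compound 3 `CCC(C)C(C#CC(=O)OC)O/C=C/C(=O)OC` has not yet been measured. It differs from compound 2 by one change: ethyl in place of phenyl on a saturated chain carbon bound to two saturated chain carbons in words, ethyl in place of phenyl on a saturated chain carbon bound to two saturated chain carbons.

For the measured compounds named here, no two measured compounds differ in only one place, so no earlier step shows how much such a swap might matter. The expectation therefore starts from compound 2 at 490 nM and is a cautious one, with a wide margin. The estimated change is a 4.1-fold higher number from compound 2 to compound 3 (0.61 log units; beyond the scatter) toward weaker inhibition of growth, a moderate step beyond the usual scatter. For compound 3 the expected value is 2000 nM in this assay with an estimated range from 500 nM to 10000 nM as the likely span.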

Compound 3, concentration for 50% growth inhibition: 340 nM
Compound 3: middle estimate off by 5.9-fold (0.77 log units), on the high side, and the stated range ends above it.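

Putting ethyl in place of phenyl on a saturated chain carbon bound to two saturated chain carbons gives, in this assay, a 1.4-fold lower number from compound 2 to compound 3 (0.16 log units; within the scatter) and so leaves the two compounds indistinguishable on this read-out. This is the only pair shown that differs in one place, and it gives the first direct look at this position: in this pair, the phenyl ring is not needed to keep growth inhibition at this level, since ethyl, a small chain with no ring, serves as well. Nothing measured here explains why the two groups give matching results.

As far as these compounds go, whether this tolerance extends to other groups at this position remains open, for instance a longer chain, an amine or a carboxylic acid, and two compounds cannot show how far it reaches. Among the compounds shown here, compound 1 gives > 100000 nM as a limit and not a number, and it differs from the other compounds in more than one place, so no step to it can be read.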